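Adding one methyl to compound 1

The compounds below may be only part of what the source reports. "The series", "measured", "known", "first", "only" and "open" are said of these compounds alone.

For the measured compounds named here, in a functional assay on SK-MEL-5 cells (Homo sapiens) for antiproliferative activity (on this read-out higher numbers stand for weaker inhibition of growth and lower numbers for stronger inhibition of growth), compound 1 (`Oc1cc(-c2ccc3ccccc3c2)nc2ncccc12`) gives 3470 nM as the higher of the two values known so far. Compound 2 (`Cc1cc(C)c2c(O)cc(-c3cccc(F)c3)nc2n1`) gives 37.2 nM in this assay as the lower one, a gap beyond the usual scatter, but it differs from compound 1 in more than one place. Compound 3 (`Cc1ccnc2nc(-c3ccc4ccccc4c3)cc(O)c12`) keeps the core of compound 1 and has methyl in place of hydrogen on an aromatic carbon, opposite the ring nitrogen (methyl in place of hydrogen on an aromatic carbon). Going by the values given here, no measured pair shows this change alone, so any forecast is loose. A moderate step toward stronger inhibition of growth, beyond the scatter, is expected in this assay, resting only on compound 2 at 37.2 nM with methyl on its core. The expected step of a 3.9-fold lower number from compound 1 to compound 3 (0.59 log units; beyond the scatter) is an estimate. For compound 3 the estimated value is 900 nM within an expected range of 150 nM to 5000 nM in this test.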

Compound 3, concentration for 50% growth inhibition: 437 nM
Compound 3: the middle estimate sits 2.1-fold (0.31 log units) above what was measured; the measured number falls inside the stated range.
By their numbers in this assay, from the lowest: compound 2; then compound 3; then compound 1.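

In this assay, methyl in place of hydrogen on an aromatic carbon, opposite the ring nitrogen, gives a 7.9-fold lower number from compound 1 to compound 3 (0.90 log units; beyond the scatter) and thus stronger inhibition of growth, a gain beyond the usual scatter. This pair isolates the change, whereas compound 2 differs from compound 1 in more than one place and could not show what this position alone contributes. The step shows that one added carbon at this position can matter on the core of compound 1, but nothing at hand explains why.

From the compounds shown here alone, it remains open whether an ethyl group, a longer chain or an amine at this position would strengthen inhibition further or weaken it. One pair also cannot show whether methyl would produce a similar step at another position on the core.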